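Rearranging a urea on a fused bicyclic sulfone

This account rests on a few compounds, and the source may have more. Where it says the series, first, only, none or still open, it means among the compounds named here.

Measured compounds:
Compound 1, `NC[C@@H]1CCCc2cc(S(=O)(=O)c3cccc(F)c3)ccc21`, gives 0.0794 nM in an assay on isolated protein for displacement of a labelled ligand from 5-hydroxytryptamine receptor 6 (Homo sapiens); a higher number here means a weaker inhibitor, a lower number a stronger inhibitor.
Compound 2, `O=S(=O)(c1cccc(F)c1)c1ccc2c(c1)CCC[C@H]2CNCCO`, gives 0.126 nM in this assay.
Compound 3, `CNC(=O)NC[C@@H]1CCCc2cc(S(=O)(=O)c3cccc(F)c3)ccc21`, gives 0.398 nM in this assay.

Compound 3 stands highest of the three numbers in this assay. Its nearest neighbour is compound 2, reached by a 3.2-fold higher number from compound 2 to compound 3 (0.50 log units; beyond the scatter), and its furthest is compound 1, reached by a 5.0-fold higher number from compound 1 to compound 3 (0.70 log units; beyond the scatter). Both steps go in the same direction and lie beyond the scatter, while a 1.6-fold higher number from compound 1 to compound 2 (0.20 log units; within the scatter) stays within it.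

Compound 4, `CN(C[C@@H]1CCCc2cc(S(=O)(=O)c3cccc(F)c3)ccc21)C(N)=O`, differs from compound 3 in one place: carbamoyl(methyl)amino in place of (methylcarbamoyl)amino on a saturated chain carbon bound to a saturated ring carbon. The two compounds have the same atoms, joined differently, so the change is an exchange of where the methyl sits within the urea and a loss of one hydrogen-bond donor.

Within the data shown here, no measured step in this set alters a group in exactly this way. Among the measured compounds shown here, the steps that bear on it only loosely are those at the amine nitrogen: the hydroxyethyl addition was within the scatter, while the urea formation was a modest weakening. Moving a methyl within an existing urea is expected to be a smaller matter than either, so no step beyond the scatter is expected in this assay, with a slight lean toward a weaker number.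

Compound 4 is therefore estimated at 0.55 nM, between 0.18 nM and 1.7 nM, which means an expected step of a 1.4-fold higher number from compound 3 to compound 4 (0.14 log units; within the scatter).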

Compound 4, inhibition constant: 39.8 nM
Beside the measured number, compound 4's estimate is 72-fold (1.86 log units) below it; measured number outside the range, above it.
By their numbers in this assay, from the lowest: compounds 1 and 2 (each within the scatter of the next); then compound 3; then compound 4.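

In this assay, among these compounds, the place on a saturated chain carbon bound to a saturated ring carbon proves far more sensitive to how the urea is arranged than the earlier compounds showed: exchanging (methylcarbamoyl)amino for carbamoyl(methyl)amino, two groups with the same atoms, gives a 100-fold higher number from compound 3 to compound 4 (2.00 log units; beyond the scatter) and far exceeds the change that forming the urea brought (a 5.0-fold higher number from compound 1 to compound 3 (0.70 log units; beyond the scatter)). The same group also stands well apart from the other two compounds, with a 320-fold higher number from compound 2 to compound 4 (2.50 log units; beyond the scatter) against the (2-hydroxyethyl)amino compound and a 500-fold higher number from compound 1 to compound 4 (2.70 log units; beyond the scatter) against the amino compound, so the presence of a urea at this place does not by itself set the number. Nothing available here accounts for so large a difference between the two arrangements.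

The compounds shown leave open whether the methyl on the nitrogen bound to the chain carbon or the loss of a hydrogen-bond donor carries the change, a question that an unmethylated urea or a urea with a methyl on each nitrogen would address. Also open, going by these compounds, is how an acetamide or a methanesulfonamide would fare at this place.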